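The source may hold more compounds than are shown below. What is called first, only, known or untested is meant among the compounds shown, and "the series" means these compounds.

Measured compounds:
compound 1 `CCN(C)C(=O)/C=C1\CCc2c(F)cc(F)cc21` — 100%
compound 2 `O=C(/C=C1\CCc2c(F)cc(F)cc21)NC1CC1` — 100%

In a functional assay on the whole organism with Mus musculus as the target, at a dose of 100 mg/kg by the intraperitoneal route (a higher number here means more inhibition at the dose given (going by the name of the read-out), a lower number less inhibition), compound 1 gives 100%, and in this assay compound 2 gives 100%. Compound 1 is therefore level with compound 2 at the digits shown; the only measured step, no change at the digits printed from compound 1 to compound 2 (within the scatter), swaps one amide substituent for another and leaves the read-out unchanged within the scatter.

Compound 3 `CCN(C)C(=O)/C=C1\CCc2ccc(F)cc21` differs from compound 1 in a different place, on the ring: hydrogen in place of fluoro on an aromatic carbon. Within the data shown here, no measured step touches this part of the shared core, so nothing measured bears directly on it. Among the measured compounds shown here, the number for compound 1 in this assay, 100%, leaves room only for a lower number, and the single measured change elsewhere did not move the read-out. Compound 3 is thus expected to stay near the top, with the step of a number 10 percentage points lower from compound 1 to compound 3 (within the scatter) expected to be small. The estimate for compound 3 is 90%, ranging from 55% to 100%.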

Compound 3, a percentage reported as inhibition, in the whole organism at one dose (the size of the read-out at that dose, not a potency): 100%
The estimate for compound 3 lay 10 percentage points below the measured number; the measured number falls inside the stated range.
By their numbers in this assay, from the lowest: compounds 1, 2 and 3 (each within the scatter of the next).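

In this assay there is no change at the digits printed from compound 1 to compound 3 (within the scatter), so this fluoro group on an aromatic carbon can give way to hydrogen without any visible loss at this dose. The earlier pair spoke only about the substituent on the amide, whereas this step shows that the ring of the shared core need not carry both fluoro groups for the read-out to stay at the top of its scale. That read-out is the size of the effect at one dose and not a potency, and it cannot rise further, so a real difference between the two compounds could stay hidden at this dose.

From the compounds shown here alone, whether a larger group at this place, such as methoxy or trifluoromethyl, would keep the read-out at the top remains open. So does the effect of replacing the remaining fluoro group with hydrogen. No measurement at hand offers an explanation for this result.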